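The source may report more compounds than this note shows. Statements on the series, on what has been measured and on what is new or still open speak of the compounds shown alone.

Measured compounds and their readings:
compound 1 `O=C(O)CCCCCNC(=O)c1cc(=O)c2ccccc2o1`: 0%
compound 2 `CC(=O)Oc1ccc2c(=O)cc(C(N)=O)oc2c1`: "nd(insoluble)" (no result reported)
compound 3 `Cc1c(C(=O)Nc2nnn[nH]2)oc2ccccc2c1=O`: 70%

In a functional assay on the whole organism for inhibition, with Rattus norvegicus as the target, with a stated time of 30 min, at a dose of 1 mg/kg by the intravenous route (on this read-out lower numbers stand for less inhibition and higher numbers for more inhibition at the one dose given (going by the name of the read-out)), compound 1 gives 0%, the lower of the two numbers reported. Compound 3 gives 70% in this assay, a reading higher than that of compound 1 and beyond the usual scatter. For compound 2 no number was obtained in this assay, as the result "nd(insoluble)" (no result reported) records.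

Compound 4 `O=C(O)CCCNC(=O)c1cc(=O)c2ccccc2o1` differs from compound 1 in one place: carboxy in place of 2-carboxyethyl on a saturated chain carbon, three bonds along the chain from an amide-type nitrogen. For the measured compounds named here, no measured pair shows this kind of change, so nothing beyond the two structures supports a prediction. The expected step from compound 1 to compound 4 in this assay is a number 5 percentage points higher from compound 1 to compound 4 (within the scatter), within the scatter. Compound 4 is therefore estimated to give 5%, between 0% and 25%.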

Compound 4, a percentage reported as inhibition, in the whole organism at one dose (the size of the read-out at that dose, not a potency): 0%
Compound 4: middle estimate off by 5 percentage points, on the high side; the measured number falls inside the stated range.
By their numbers in this assay, from the lowest: compounds 1 and 4 (each within the scatter of the next); then compound 3.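

Carboxy in place of 2-carboxyethyl on a saturated chain carbon, three bonds along the chain from an amide-type nitrogen, gives no change at the digits printed from compound 1 to compound 4 (within the scatter) in this assay. At this position, then, the shorter chain with its carboxy end reads no differently from the longer one at the one dose given. Nothing shown explains this result. As far as these compounds go, it remains open whether an amine in place of the carboxy group, or a chain longer than that of compound 1, would give a different reading in this assay.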